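The source may hold more compounds than are shown below. What is called first, only, known or untested is meant among the compounds shown, and "the series" means these compounds.

Compound 1 `Cc1ccc(C(=O)c2ccc(OCC(=O)Nc3nc(-c4ccccc4)cs3)c(C)c2)cc1` gives 26400 nM in a functional assay on DLA cells (Mus musculus) for cytotoxicity, read by MTT assay, with a stated time of 48 h; on this read-out higher numbers stand for weaker inhibition and lower numbers for stronger inhibition. On the numbers at hand compound 1 stands with compound 2 `COc1ccc(-c2csc(NC(=O)COc3ccc(C(=O)c4ccc(C)cc4)cc3C)n2)cc1` within the scatter of it: compound 2 gives 17200 nM in this assay, and the step of a 1.5-fold lower number from compound 1 to compound 2 (0.19 log units; within the scatter) stays within the scatter. Compound 3 `Cc1cc(C(=O)c2ccccc2F)ccc1OCC(=O)Nc1nc(-c2ccccc2)cs1` differs from compound 1 by 2-fluorophenyl in place of 4-methylphenyl on a carbonyl carbon. For the measured compounds named here, the only step measured, from compound 1 to compound 2, sits on a different place and does not bear on a change at the carbonyl carbon, so no step beyond the scatter is expected. Compound 3 is therefore estimated at 24000 nM, with a range from 8000 nM to 70000 nM, a step of a 1.1-fold lower number from compound 1 to compound 3 (0.04 log units; within the scatter).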

Compound 3, half-maximal inhibitory concentration: 14800 nM
The estimate for compound 3 lay 1.6-fold (0.21 log units) above the measured number; measured number inside the range.
By their numbers in this assay, from the lowest: compounds 3, 2 and 1 (each within the scatter of the next).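

For the compounds shown here, the first change at the carbonyl carbon, 2-fluorophenyl in place of 4-methylphenyl, gives a 1.8-fold lower number from compound 1 to compound 3 (0.25 log units; within the scatter) in this assay. This position therefore accepts that exchange of one aromatic ring for another without a step beyond the scatter, as the methoxy change elsewhere in compound 2 also did. No measurement at hand bears on the reason for this result. Going by these compounds, what an amine or a carboxylic acid at the carbonyl carbon would give remains open, as does whether any change there can move the number beyond the scatter.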